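A few compounds are considered here, and "the series" means these few. Any claim that something is new, unique, unknown or untested is made for them only; others in the source may bear on it.

In a functional assay on MGC-803 cells (Homo sapiens) for antiproliferative activity, read by MTT assay, with a stated time of 48 h (a lower number here means a stronger inhibitor, a higher number a weaker inhibitor), compound 1 `COc1cc(N(Cc2ccc(C)cc2)C(=O)CSc2nc3ccccc3s2)cc(OC)c1OC` gives 54200 nM, compound 2 `COc1ccc(CN(C(=O)CSc2nc3ccccc3s2)c2cc(OC)c(OC)c(OC)c2)cc1O` gives 35 nM and compound 3 `COc1ccc2nc(SCC(=O)N(Cc3ccc(OC)c(O)c3)c3cc(OC)c(OC)c(OC)c3)sc2c1` gives 71 nM, the second highest of the three numbers, much nearer compound 2 than compound 1. Compound 4 `COc1ccc(CN(C(=O)CSc2nc3cc(Cl)ccc3s2)c2cc(OC)c(OC)c(OC)c2)cc1O` carries 5-chloro-1,3-benzothiazol-2-yl in place of 6-methoxy-1,3-benzothiazol-2-yl on a sulfur. Among the measured compounds shown here, the one measured change in this group is modest: a 2.0-fold higher number from compound 2 to compound 3 (0.31 log units; beyond the scatter). The large step, a 1500-fold lower number from compound 1 to compound 2 (3.19 log units; beyond the scatter), concerns a different group and does not bear on this change. For the measured compounds named here, no chloro compound has been measured, so only a small move toward a lower number is expected in this assay, possibly none beyond the scatter. The expected step is a 1.2-fold lower number from compound 3 to compound 4 (0.07 log units; within the scatter). For compound 4 the estimated value is 60 nM, with a range of 20 nM to 250 nM.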

Compound 4, half-maximal inhibitory concentration: 85 nM
The estimate for compound 4 lay 1.4-fold (0.15 log units) below the measured number; the range from low to high includes it.
By their numbers in this assay, from the lowest: compound 2; then compounds 3 and 4 (each within the scatter of the next); then compound 1.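

In this assay, chloro in place of hydrogen on an aromatic carbon gives a 2.4-fold higher number from compound 2 to compound 4 (0.39 log units; beyond the scatter), so a second substituent on this ring system joins methoxy in a modest step away from the unsubstituted compound 2. Exchanging 6-methoxy-1,3-benzothiazol-2-yl for 5-chloro-1,3-benzothiazol-2-yl gives a 1.2-fold higher number from compound 3 to compound 4 (0.08 log units; within the scatter), which leaves the two substituted compounds indistinguishable in this assay. No measurement available here accounts for this result.

Going by these compounds, the exchange changes the group and its ring location together, so their separate contributions remain open. On these data alone, the effect of an amine or a carboxylic acid on this ring also remains open.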